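Swapping a Methylphenyl for a Chlorofluorophenyl Side Group

This account rests on a few compounds, and the source may have more. Where it says the series, first, only, none or still open, it means among the compounds named here.

Compound 1 `Cc1ccc(CNc2ncnc3c2ncn3[C@@H]2O[C@H](CO)[C@@H](O)[C@H]2O)cc1` was tested in a functional assay on CCRF-CEM cells (Homo sapiens) for antiproliferative activity, with a stated time of 72 h; on this read-out higher numbers stand for weaker inhibition and lower numbers for stronger inhibition. In this assay compound 1 gives only a limit, > 166000 nM, which is not a measured number. This limit sits at the limit of > 166000 nM in this assay, at which 1 of the 2 values shown sits, so where compound 1 truly stands is not known, only that its inhibition is weak. Compound 2 `OC[C@H]1O[C@@H](n2cnc3c(NCc4cc(F)cc(F)c4)ncnc32)C(O)C1O` carries the same core with a different side group, and in this assay compound 2 gives 24500 nM; the two values show that compound 2 inhibits more strongly than compound 1, with a gap well beyond the usual scatter.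

Compound 3 `OC[C@H]1O[C@@H](n2cnc3c(NCc4ccc(F)cc4Cl)ncnc32)[C@H](O)[C@@H]1O` has not yet been measured. It differs from compound 1 by 2-chloro-4-fluorophenyl in place of 4-methylphenyl on a saturated chain carbon bound to a nitrogen on an aromatic ring. For the measured compounds named here, no measured step joins compound 1 to compound 3, so the expectation rests on compound 2, whose value of 24500 nM shows that a side group of this kind on the shared core can reach measurable inhibition. The step from compound 1 to compound 3 is expected to be an at least 5.5-fold lower number from compound 1 to compound 3 (0.74 log units; beyond the scatter), towards stronger inhibition. Compound 3 is estimated to give 30000 nM, with a range of 8000 nM to 120000 nM.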

Compound 3, half-maximal inhibitory concentration: 20900 nM
Beside the measured number, compound 3's estimate is 1.4-fold (0.16 log units) above it, and the stated range covers the measured number.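

For the compounds shown here, at this position, on a saturated chain carbon bound to a nitrogen on an aromatic ring, the result gives the first direct reading of a side-group change in this assay: 2-chloro-4-fluorophenyl in place of 4-methylphenyl gives an at least 7.9-fold lower number from compound 1 to compound 3 (0.89 log units; beyond the scatter). As far as these compounds go, the true size of this step stays unknown because compound 1 gives only a limit, not a measured number: the limit of > 166000 nM in this assay, at which 1 of the 3 values shown sits. Both groups are six-membered aromatic rings of carbon only, with no hydrogen-bond donors or acceptors, so the step shows that changing what the ring carries is enough to reach a measured value, with compound 3 at 20900 nM.

The change removes one methyl and adds a chlorine and a fluorine at once, so these compounds cannot tell how much of the step belongs to each halogen, or to losing the methyl; a plain 2-chlorophenyl or 4-fluorophenyl group would separate these parts. From the compounds shown here alone, it also remains open how this position would respond to a ring carrying an amine or a carboxylic acid, or to a longer chain between the ring and the nitrogen.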